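The source may report more compounds than this note shows. Statements on the series, on what has been measured and on what is new or still open speak of the compounds shown alone.

Two of the three compounds here share one core and differ only in the aryl group attached to the urea nitrogen. Compound 1 `Cc1ccccc1NC(=O)Nc1cccc(CNc2ncnc3ccccc23)c1` carries a 2-methylphenyl group there. In a functional assay on HepG2 cells (Homo sapiens) for antiproliferative activity, read by MTT assay (on this read-out lower numbers stand for stronger inhibition and higher numbers for weaker inhibition), compound 1 gives > 50000 nM, which is a limit of the assay and not a number. Compound 2 `COc1ccc(NC(=O)Nc2cccc(CNc3ncnc4ccccc34)c2)cc1` carries a 4-methoxyphenyl group instead. In this assay compound 2 gives > 50000 nM, again a limit rather than a number. Among the compounds with values here, the only measured step, a step that the two limits leave unreadable from compound 1 to compound 2, therefore has no readable size, because both values sit at the limit of > 50000 nM in this assay, at which 2 of the 2 values shown sit. Compound 2 thus stands at the limit of the assay, with nothing measurable placing it apart from compound 1.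

Compound 3 `O=C(Nc1ccc(F)cc1)Nc1cccc(CNc2ncnc3ccccc23)c1` is the compound still to be measured. It differs from compound 2 by fluoro in place of methoxy on an aromatic carbon. Within the data shown here, since the one measured step bears on this change only as an unreadable limit, no direction can be drawn from it, and no step beyond the scatter is expected. The step expected for this assay is a step that the limit leaves unreadable from compound 2 to compound 3. Compound 3 is accordingly estimated at 60000 nM, in a range from 20000 nM to 200000 nM, most probably reported again as a limit.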

Compound 3, half-maximal inhibitory concentration: 41500 nM
Estimate against measurement, compound 3: 1.4-fold (0.16 log units) above; the measured number falls inside the stated range.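

Compound 3 is the only one of the three whose aryl group on the urea nitrogen gives a readable number rather than a limit: in this assay compound 3 gives 41500 nM. Fluoro in place of methoxy on this aromatic carbon, para to a large group, gives an at least 1.2-fold lower number from compound 2 to compound 3 (0.08 log units; that floor lies within the scatter), and the change from the 2-methylphenyl group to the 4-fluorophenyl group gives an at least 1.2-fold lower number from compound 1 to compound 3 (0.08 log units; that floor lies within the scatter). Each of these steps is only a floor and not a full size, so the position is shown to reach a measurable value, but no real gain over compound 1 or compound 2 is established, since those two values are limits: the limit of > 50000 nM in this assay, at which 2 of the 3 values shown sit.

Going by these compounds, how far compound 3 truly lies from compound 1 and compound 2 stays open, as does whether any group on this ring can bring the number well under that of compound 3. The compounds shown also do not tell how a chloro group, an amine or a carboxylic acid would read at this same place.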